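Moving the hydroxy group on the pendant phenyl ring

A few compounds are considered here, and "the series" means these few. Any claim that something is new, unique, unknown or untested is made for them only; others in the source may bear on it.

Compound 1 `CCCS(=O)(=O)Nc1ccc(F)c(C(=O)c2n[nH]c3ncc(-c4ccccc4Cl)cc23)c1F` gives 9.3% in an assay for binding affinity to dual specificity mitogen-activated protein kinase kinase 4 (Homo sapiens), read by KINOMEscan, tested at 100 nM; on this read-out lower numbers stand for a stronger effect and higher numbers for a weaker effect at the one concentration tested.
Compound 2 `CCCS(=O)(=O)Nc1ccc(F)c(C(=O)c2n[nH]c3ncc(-c4cccc(Cl)c4)cc23)c1F` gives 40%.
Compound 3 `CCCS(=O)(=O)Nc1ccc(F)c(C(=O)c2n[nH]c3ncc(-c4ccccc4O)cc23)c1F` gives 9%.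

Compound 3 shows the lowest number of the three, although compound 1 lies within the scatter of it; compound 2 stands well above both. Compound 4 `CCCS(=O)(=O)Nc1ccc(F)c(C(=O)c2n[nH]c3ncc(-c4cccc(O)c4)cc23)c1F` differs from compound 3 by 3-hydroxyphenyl in place of 2-hydroxyphenyl on an aromatic carbon. The measured step most like this change is a number 30.7 percentage points higher from compound 1 to compound 2 (beyond the scatter), where 3-chlorophenyl replaced 2-chlorophenyl. The step of a number 0.3 percentage points lower from compound 1 to compound 3 (within the scatter) shows that swapping chloro for hydroxy alone changed little, and a number 31 percentage points lower from compound 2 to compound 3 (beyond the scatter) mirrors the first step. A rise of similar size is therefore expected for compound 4, namely a number 29 percentage points higher from compound 3 to compound 4 (beyond the scatter) in this assay. Compound 4 is accordingly estimated at 38%, with a likely range from 15% to 65%.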

Compound 4, a percentage reported as activity, at one concentration (the size of the read-out at that concentration, not a potency): 2.2%
Estimate against measurement, compound 4: 35.8 percentage points above, and the stated range ends above it.
By their numbers in this assay, from the lowest: compounds 4, 3 and 1 (each within the scatter of the next); then compound 2.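

With hydroxy, the change from 2-hydroxyphenyl to 3-hydroxyphenyl gives only a number 6.8 percentage points lower from compound 3 to compound 4 (within the scatter), so the large step seen for the chloro pair does not recur. The comparison with the 2-chlorophenyl group is similarly small, a number 7.1 percentage points lower from compound 1 to compound 4 (within the scatter), whereas the comparison with the 3-chlorophenyl group is large, a number 37.8 percentage points lower from compound 2 to compound 4 (beyond the scatter). Replacing chloro with hydroxy therefore has an effect that differs with its place on the pendant ring: the same change on two cores in this assay, a number 0.3 percentage points lower (within the scatter) from compound 1 to compound 3 and a number 37.8 percentage points lower (beyond the scatter) from compound 2 to compound 4, 37.5 percentage points apart, beyond the scatter of two such steps.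

Still open, from the compounds shown here alone, is how 4-hydroxyphenyl would read in this assay. Also open, going by these compounds, is whether an amine in place of the hydroxy would give similar numbers.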